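Swapping a fluorophenyl for a trimethoxyphenyl on a benzyl ether

The source may hold more compounds than are shown below. What is called first, only, known or untested is meant among the compounds shown, and "the series" means these compounds.

Compound 2 `Fc1ccc(COc2ccc(-c3cc(CN4CCN(Cc5ccc(C(F)(F)F)cc5)CC4)no3)cc2)cc1` and compound 1 `FC(F)(F)c1ccc(CN2CCN(Cc3cc(-c4ccc(OCc5ccc(Cl)cc5)cc4)on3)CC2)cc1` share one core and differ only in a halogen on the outer aromatic ring. In a functional assay on Mahlavu cells (Homo sapiens) for antiproliferative activity, read by sulforhodamine B assay, with a stated time of 72 h (a lower number here means a stronger inhibitor, a higher number a weaker inhibitor), compound 2 gives 3100 nM, and compound 1 gives 3700 nM. For the measured compounds named here, the step of a 1.2-fold lower number from compound 1 to compound 2 (0.08 log units; within the scatter) is the only measured comparison available, and it lies within the scatter, so the two values cannot be told apart; compound 2 is simply one of two closely matched numbers.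

Compound 3 `COc1cc(COc2ccc(-c3cc(CN4CCN(Cc5ccc(C(F)(F)F)cc5)CC4)no3)cc2)cc(OC)c1OC` is not yet measured. It differs from compound 2 by 3,4,5-trimethoxyphenyl in place of 4-fluorophenyl on a saturated chain carbon bound to an oxygen on an aromatic ring. This is a much larger change than the halogen swap seen in the measured step from compound 1 to compound 2, which sits at the same ring and left the number unchanged within scatter. Nothing in the data shows how a bulkier ring with three extra acceptor atoms at this place behaves, so the expectation is uncertain and wide. The estimated step is a 1.1-fold higher number from compound 2 to compound 3 (0.05 log units; within the scatter). Compound 3 is therefore expected to give about 3500 nM in this assay, within a range from 1200 nM to 10000 nM.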

Compound 3, half-maximal inhibitory concentration: 5800 nM
The estimate for compound 3 lay 1.7-fold (0.22 log units) below the measured number; low and high end bracket the measured number.
By their numbers in this assay, from the lowest: compounds 2, 1 and 3 (each within the scatter of the next).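

In this assay, 3,4,5-trimethoxyphenyl in place of 4-fluorophenyl gives a 1.9-fold higher number from compound 2 to compound 3 (0.27 log units; within the scatter) and in place of 4-chlorophenyl gives a 1.6-fold higher number from compound 1 to compound 3 (0.20 log units; within the scatter). The earlier compounds shown here showed only that one halogen on this ring could stand in for another, whereas these steps show that the whole group on a saturated chain carbon bound to an oxygen on an aromatic ring can be exchanged for a larger one carrying hydrogen-bond acceptors, and the number still stays within the scatter. No measurement is available that would explain this result or link it to any property of the groups.

On these data alone, all three compounds carry a substituted phenyl ring at this place, so it remains open whether the same tolerance would hold for a group without such a ring, such as an amine, a carboxylic acid or a longer saturated chain. As far as these compounds go, it is also open whether a larger step would appear with an unsubstituted phenyl, or with a single methoxy group in place of the three on this ring.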